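Thiophen-2-yl in Place of 2-Chlorophenyl on an Imine Carbon

A few compounds are considered here, and "the series" means these few. Any claim that something is new, unique, unknown or untested is made for them only; others in the source may bear on it.

Among the measured compounds shown here, compound 1 `CS(=O)(=O)c1ccc(Cc2n[nH]c(=S)n2/N=C/c2ccccc2Cl)cc1` is one of two compounds measured so far. In a functional assay on HeLa cells (Homo sapiens) for cytotoxicity, read by MTT assay, with a stated time of 48 h, tested at 100 uM (a higher number here means a stronger effect of the compound at the concentration tested, a lower number a weaker effect), compound 1 gives 76.5%, the highest of the two values. The other compound, compound 2 `COc1ccc2cc(/C=N/n3c(Cc4ccc(S(C)(=O)=O)cc4)n[nH]c3=S)ccc2c1`, gives 64.6% in this assay, a lower value, and the gap between the two lies beyond the usual scatter of repeated measurements. For the measured compounds named here, no pair of measured compounds differs in a single place, so there is no measured step to show how large one change of this kind tends to be.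

Compound 3 `CS(=O)(=O)c1ccc(Cc2n[nH]c(=S)n2/N=C/c2cccs2)cc1` has not yet been measured. It differs from compound 1 by thiophen-2-yl in place of 2-chlorophenyl on a carbon with a double bond to nitrogen. Since compound 1 gives 76.5%, only a modest step is expected from compound 1 to compound 3, a number 8.5 percentage points lower from compound 1 to compound 3 (within the scatter), likely downward but possibly within the scatter. Compound 3 is estimated to give 68% in this assay, with a range from 50% to 85%.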

Compound 3, a percentage reported as activity, at one concentration (the size of the read-out at that concentration, not a potency): 61.1%
For compound 3 the middle estimate is 6.9 percentage points above the measured one; the measured number falls inside the stated range.
By their numbers in this assay, from the lowest: compounds 3 and 2 (each within the scatter of the next); then compound 1.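

Thiophen-2-yl in place of 2-chlorophenyl on a carbon with a double bond to nitrogen gives the first change in one place that can be read, and in this assay it amounts to a number 15.4 percentage points lower from compound 1 to compound 3 (beyond the scatter). The read-out at this single concentration therefore responds to the group on this carbon, and the exchange of one aromatic ring for another is enough to move it beyond the scatter. Nothing at hand bears on what lies behind this step.

The compounds shown leave open whether the step follows the chlorine or the ring itself, a question that a plain phenyl on this carbon would bear on. They also leave open how this carbon would tolerate a non-aromatic group such as a cyclohexyl or a longer alkyl chain, or a ring carrying an amine or a carboxylic acid.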